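The source may hold more compounds than are shown below. What is called first, only, known or untested is meant among the compounds shown, and "the series" means these compounds.

Measured compounds:
compound 1 `Fc1cccc(C(F)(F)F)c1-c1ccc2[nH]c(C3=NOC4(CCCCC4)C3)nc2c1` gives 0.6 nM in a functional assay on HEK293 cells for antagonist activity at transient receptor potential M8 protein (Canis lupus familiaris), read by FLIPR and calcium flux; on this read-out higher numbers stand for weaker inhibition and lower numbers for stronger inhibition
compound 2 `Fc1cc(-c2ccccc2C(F)(F)F)cc2nc(C3=NOC4(CCCCC4)C3)[nH]c12` gives 2.2 nM in this assay

Compound 2 holds the higher of the two numbers seen so far. Compound 1 gives 0.6 nM in this assay, a lower number, and the gap between the two lies beyond the usual scatter of repeated measurements, so compound 1 is the stronger inhibitor of the pair. The two compounds share a common core and differ in where a fluoro and the 2-(trifluoromethyl)phenyl group sit on that core; no single-point step between them is shown, so their two values are simply taken as they stand.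

Compound 3 `OCCCc1cc(-c2ccccc2C(F)(F)F)cc2nc(C3=NOC4(CCCCC4)C3)[nH]c12` is not yet measured. It arises from compound 2 by one change: 3-hydroxypropyl in place of fluoro on an aromatic carbon. Going by the values given here, no pair already measured shows what such a swap does, so the size of the step is unknown. A modest weakening is expected, within a range that also allows no change beyond the scatter, and the step from compound 2 to compound 3 is estimated as a 2.3-fold higher number from compound 2 to compound 3 (0.36 log units; beyond the scatter). On that basis compound 3 is expected to give about 5 nM in this assay, with a plausible range from 1 nM to 30 nM.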

Compound 3, half-maximal inhibitory concentration: 0.2 nM
The estimate for compound 3 lay 25-fold (1.40 log units) above the measured number, outside the stated range (below it).
By their numbers in this assay, from the lowest: compound 3; then compound 1; then compound 2.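

Going by these compounds alone, this aromatic carbon, ortho to a fused ring and meta to a 2-(trifluoromethyl)phenyl group, had so far been seen carrying only a fluoro group, so nothing showed how much room for change it offered. Replacing that single fluorine with the four heavy atoms of 3-hydroxypropyl gives an 11-fold lower number from compound 2 to compound 3 (1.04 log units; beyond the scatter) in this assay, a large step toward stronger inhibition. The position therefore accepts a longer chain carrying one hydrogen-bond donor and one hydrogen-bond acceptor, and this particular chain is clearly better here than fluoro.

The compounds shown do not separate the contribution of the chain from that of its hydroxyl group: a plain propyl chain would address that, while hydroxymethyl, a longer hydroxyalkyl chain, or a chain ending in an amine or a carboxylic acid would show how far the gain extends. Going by these compounds, it also remains open whether 3-hydroxypropyl would bring a similar gain on the core of compound 1, where the substituents are arranged differently. No measurement shown here explains the size of this step.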